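Extending the Amine Chain Beyond Compound 2

This account rests on a few compounds, and the source may have more. Where it says the series, first, only, none or still open, it means among the compounds named here.

Compound 1 `CCCCCCCCNC[C@@H]1OC[C@H](N)[C@@H]1O`: > 128000 nM (a limit of the assay, not a number)
Compound 2 `CCCCCCCCCCCCNC[C@@H]1OC[C@H](N)[C@@H]1O`: 5870 nM

Within the data shown here, in a functional assay on A549 cells (Homo sapiens) for antiproliferative activity, read by MTT assay, with a stated time of 72 h (a lower number here means a stronger inhibitor, a higher number a weaker inhibitor), compound 2 gives 5870 nM, the only actual number so far. Compound 1 stands at > 128000 nM, which is a limit and not a number. Compound 3 `CCCCCCCCCCCCCCNC[C@@H]1OC[C@H](N)[C@@H]1O` differs from compound 2 in one place: ethyl in place of hydrogen on a saturated chain carbon, ten or more bonds along the chain from an amine nitrogen. That puts ethyl in place of hydrogen on a saturated chain carbon, ten or more bonds along the chain from an amine nitrogen.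

Among the measured compounds shown here, only one measured step bears on this change, a large one of the same kind, with butyl entering on the chain: an at least 21-fold lower number from compound 1 to compound 2 (1.33 log units; beyond the scatter). Its size is open-ended, given (the limit of > 128000 nM in this assay, at which 1 of the 2 values shown sits). One step is thin evidence and the group entering here is smaller, so only a modest move towards a lower number is expected in this assay. The expected step is a 1.7-fold lower number from compound 2 to compound 3 (0.22 log units; within the scatter). Compound 3 is estimated at 3500 nM, with an expected range of 1300 nM to 11000 nM.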

Compound 3, half-maximal inhibitory concentration: 2850 nM
For compound 3 the middle estimate is 1.2-fold (0.09 log units) above the measured one, and the stated range covers the measured number.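

In this assay the chain on the amine nitrogen can grow past the length in compound 2 and the number still falls, with a 2.1-fold lower number from compound 2 to compound 3 (0.31 log units; beyond the scatter) for ethyl in place of hydrogen at this place. This is a modest move, yet it lies beyond the scatter, so the trend seen so far does not stop at compound 2, and no compound shown goes against it. Over the whole series the change gives an at least 44-fold lower number from compound 1 to compound 3 (1.65 log units; beyond the scatter), and the true size of that step stays open-ended, as compound 1 carries a limit and not a number: the limit of > 128000 nM in this assay, at which 1 of the 3 values shown sits.

The compounds shown leave open whether a longer chain would lower the number further or raise it again. They also leave open whether a chain ending in a hydroxyl group or a phenyl ring would keep this gain.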